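A few compounds are considered here, and "the series" means these few. Any claim that something is new, unique, unknown or untested is made for them only; others in the source may bear on it.

Of the compounds shown here, two built on one shared core have been measured so far in a functional assay on HepG2 cells (Homo sapiens) for inhibition, read by MTT assay; a lower number here means a stronger inhibitor, a higher number a weaker inhibitor. Compound 1 (`COc1cc2ncnc(Nc3ccc(NC(=O)c4cccc(F)c4)cc3)c2cc1OC`) gives 8200 nM, and compound 2 (`COc1cc2ncnc(Nc3ccc(NC(=O)c4ccc(Br)cc4)cc3)c2cc1OC`) gives 35000 nM. Compound 2 therefore holds the higher of the two numbers and is the weaker inhibitor of the pair. Going by the values given here, the one measured step, a 4.3-fold higher number from compound 1 to compound 2 (0.63 log units; beyond the scatter), is modest but lies beyond the usual scatter.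

Compound 3 (`COc1cc2ncnc(Nc3ccc(NC(=O)c4c(F)cccc4F)cc3)c2cc1OC`) keeps the core and changes the ring, with 2,6-difluorophenyl in place of 4-bromophenyl on a carbonyl carbon. Among the compounds with values here, only that single step bears on this change, and two compounds cannot establish a trend. Still, compound 3 carries fluorine and no bromine, as does compound 1 at 8200 nM, so a lower number than that of compound 2 seems the better expectation. The size is expected to be similar to that measured step or somewhat smaller. The estimated change is a 2.3-fold lower number from compound 2 to compound 3 (0.37 log units; beyond the scatter). In this assay the estimate for compound 3 is 15000 nM, with an expected range of 5000 nM to 40000 nM.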

Compound 3, half-maximal inhibitory concentration: 17000 nM
For compound 3 the middle estimate is 1.1-fold (0.05 log units) below the measured one, within the range that was stated.
By their numbers in this assay, from the lowest: compound 1; then compound 3; then compound 2.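

In this assay, the ring on the carbonyl carbon now has three measured forms, and compound 3 sits in the middle of them: 2,6-difluorophenyl in place of 4-bromophenyl gives a 2.1-fold lower number from compound 2 to compound 3 (0.31 log units; beyond the scatter), while 2,6-difluorophenyl in place of 3-fluorophenyl gives a 2.1-fold higher number from compound 1 to compound 3 (0.32 log units; beyond the scatter). Both steps are modest but beyond the scatter, so a ring carrying fluorine and no bromine does not by itself match compound 1, which keeps the lowest number of the three. Nothing available explains why these rings rank in this order.

Each of the three rings differs from the others in the kind of halogen, the number of halogens or where they sit, and these compounds cannot separate those changes from one another. As far as these compounds go, it also remains open where an unsubstituted phenyl, a 4-fluorophenyl or a phenyl ring carrying an amine would fall relative to compound 1, and whether any change at this position could give a much lower number.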